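The source may report more compounds than this note shows. Statements on the series, on what has been measured and on what is new or still open speak of the compounds shown alone.

In a functional assay on the whole organism for inhibition, with Rattus norvegicus as the target, with a stated time of 30 min, at a dose of 1 mg/kg by the intravenous route (a lower number here means less inhibition, a higher number more inhibition at the dose given (going by the name of the read-out)), compound 1, `O=C(Nc1nnn[nH]1)c1cc(=O)c2ccccc2o1`, gives 100%. Compound 2, `O=C(Nc1nnn[nH]1)c1oc2ccccc2c(=O)c1Cl`, gives 75% in this assay, and the step of a number 25 percentage points lower from compound 1 to compound 2 (beyond the scatter) reflects a chloro in place of hydrogen on an aromatic carbon. Compound 2 therefore stands lowest of the two measured compounds, with compound 1 the nearest neighbour and higher by a margin beyond the scatter.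

Compound 3, `CNc1c(C(=O)Nc2nnn[nH]2)oc2ccccc2c1=O`, is the next compound to be measured in this assay. It differs from compound 2 by methylamino in place of chloro on an aromatic carbon. Going by the values given here, the only measured step that bears on this position is the one from compound 1 to compound 2, where adding chloro lowered inhibition modestly. Among the compounds with values here, nothing measured so far shows what methylamino does at this position, so the step from compound 2 to compound 3 is uncertain. Because the chloro that lowered the number in a number 25 percentage points lower from compound 1 to compound 2 (beyond the scatter) is removed, compound 3 is expected to move somewhat upward, by a step of about a number 5 percentage points higher from compound 2 to compound 3 (within the scatter). Compound 3 is estimated to give 80% in this assay, within a range from 50% to 100%.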

Compound 3, a percentage reported as inhibition, in the whole organism at one dose (the size of the read-out at that dose, not a potency): 100%
For compound 3 the middle estimate is 20 percentage points below the measured one; the range from low to high includes it.
By their numbers in this assay, from the lowest: compound 2; then compounds 1 and 3 (each within the scatter of the next).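

In this assay the change of chloro to methylamino gives a number 25 percentage points higher from compound 2 to compound 3 (beyond the scatter) and so reverses the loss seen in a number 25 percentage points lower from compound 1 to compound 2 (beyond the scatter) at the same aromatic carbon. This shows that the lower number seen with chloro does not extend to every group placed here, and the step of no change at the digits printed from compound 1 to compound 3 (within the scatter) shows that methylamino can occupy this position, two atoms from the ring oxygen, with no measurable cost in inhibition relative to hydrogen at this single dose. No measurement available here explains why the two groups differ, as the comparison shows only the size of each step and nothing about its cause.

The compounds shown leave open whether the result belongs to methylamino alone or extends to other nitrogen groups, such as a plain amine, dimethylamino or the longer ethylamino chain, and whether another halogen such as fluoro or bromo would behave like chloro. They also leave open how compound 3 and compound 1 would compare at a lower dose, since a reading at one dose gives the size of the effect there and not a potency.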